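A few compounds are considered here, and "the series" means these few. Any claim that something is new, unique, unknown or untested is made for them only; others in the source may bear on it.

Compounds measured in an assay on HL-60 cells for agonist activity at vitamin D3 receptor (Homo sapiens), read by microscopy, with a stated time of 96 h; a lower number here means that less compound is needed, a higher number that more compound is needed for the effect:
compound 1 `CCn1c(C(=O)N(C)c2ccccc2)ccc1C(CC)(CC)c1ccc(OCC(=O)C(C)(C)C)c(C)c1`: 18500 nM
compound 2 `CCn1c(C(=O)N(C)c2ccccc2)ccc1C(CC)(CC)c1ccc(OCC(O)C(C)(C)C)c(C)c1`: 6400 nM
compound 3 `C#CCCOC(=O)c1ccc(C(CC)(CC)c2ccc(OCC(O)C(C)(C)C)c(C)c2)n1CC`: 1030 nM

Compound 1 needs the most compound of the three: compound 2 sits nearest, with a 2.9-fold lower number from compound 1 to compound 2 (0.46 log units; beyond the scatter), and compound 3 sits furthest, with a 6.2-fold lower number from compound 2 to compound 3 (0.79 log units; beyond the scatter) carrying it further down from compound 2. The unmeasured compound 4 `CCOC(=O)c1ccc(OC(=O)c2ccc(C(CC)(CC)c3ccc(OCC(=O)C(C)(C)C)c(C)c3)n2CC)cc1` is compound 1 with one part exchanged on a carbonyl carbon: 4-(ethoxycarbonyl)phenoxy in place of methyl(phenyl)amino on a carbonyl carbon. Among the compounds with values here, only one measured step touches that same carbonyl carbon: the move from compound 2 to compound 3, where an oxygen-linked chain took the place of methyl(phenyl)amino and the number fell by a 6.2-fold lower number from compound 2 to compound 3 (0.79 log units; beyond the scatter). Compound 4 also puts an oxygen-linked group on that carbonyl carbon, though a larger one, so a step of roughly that kind, downward, is expected for compound 4, namely a 5.0-fold lower number from compound 1 to compound 4 (0.70 log units; beyond the scatter). Within the data shown here, the estimate for compound 4 is therefore 3700 nM, expected to lie between 1000 nM and 12000 nM given the single related step.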

Compound 4, half-maximal effective concentration: 45600 nM
Compound 4: the middle estimate sits 12-fold (1.09 log units) below what was measured, and the stated range ends below it.
By their numbers in this assay, from the lowest: compound 3; then compound 2; then compound 1; then compound 4.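

In this assay, putting 4-(ethoxycarbonyl)phenoxy in place of methyl(phenyl)amino on the carbonyl carbon gives a 2.5-fold higher number from compound 1 to compound 4 (0.39 log units; beyond the scatter), so an oxygen link at this position does not by itself lower the number. The exchange for (but-3-yn-1-yl)oxy went the other way, with a 6.2-fold lower number from compound 2 to compound 3 (0.79 log units; beyond the scatter), which shows that the direction depends on what is exchanged, on the rest of the molecule, or on both, since the two steps start from different compounds. Nothing available here explains this difference in direction.

The compounds shown leave open whether the higher number follows from the whole 4-(ethoxycarbonyl)phenoxy group or from its ethyl ester alone. A plain phenoxy group or a carboxylic acid in place of the ethoxycarbonyl would separate these, and either group on the hydroxy side chain of compound 2 would test the role of the rest of the molecule.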